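The source may report more compounds than this note shows. Statements on the series, on what has been measured and on what is new or still open speak of the compounds shown alone.

Measured compounds: compound 1 `CCCCCCCCCCCCCCCCCCNC(=O)[C@H]1CSC(c2ccc(C#N)cc2)N1` with 5000 nM; compound 2 `CCCCCCCCCCCCCCCCCCNC(=O)[C@H]1CSC(c2cc(F)cc(F)c2)N1` with 10600 nM.

In a functional assay on PPC-1 cells (Homo sapiens) for antiproliferative activity, read by sulforhodamine B assay (on this read-out lower numbers stand for stronger inhibition and higher numbers for weaker inhibition), compound 2 gives 10600 nM, the highest of the two numbers, and its nearest neighbour compound 1 gives 5000 nM. Compound 3 `CCCCCCCCCCCCCCCCCCNC(=O)[C@H]1CSC(c2c(Cl)cccc2Cl)N1` carries 2,6-dichlorophenyl in place of 3,5-difluorophenyl on a saturated ring carbon. Among the measured compounds shown here, the only measured step at this ring, a 2.1-fold higher number from compound 1 to compound 2 (0.33 log units; beyond the scatter), was modest. For the measured compounds named here, no measured pair shows a 2,6-dichlorophenyl here. Compound 3 is therefore expected to move little, with a step of about a 1.2-fold lower number from compound 2 to compound 3 (0.07 log units; within the scatter). In this assay compound 3 is estimated at 9000 nM, with a range from 3000 nM to 30000 nM.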

Compound 3, half-maximal inhibitory concentration: 17100 nM
Estimate against measurement, compound 3: 1.9-fold (0.28 log units) below; low and high end bracket the measured number.
By their numbers in this assay, from the lowest: compound 1; then compounds 2 and 3 (each within the scatter of the next).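

In this assay the change to 2,6-dichlorophenyl brings a 1.6-fold higher number from compound 2 to compound 3 (0.21 log units; within the scatter) and so does not set this group apart from 3,5-difluorophenyl on the saturated ring carbon. Replacing 4-cyanophenyl at the same carbon brings a 3.4-fold higher number from compound 1 to compound 3 (0.53 log units; beyond the scatter) as a modest step, so compound 1 stays apart from both dihalophenyl compounds. Nothing available explains these numbers. On these data alone, whether an amine or a carboxylic acid on this aryl ring would shift the number remains open. So does the effect of a plain phenyl at this carbon.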